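A few compounds are considered here, and "the series" means these few. Any claim that something is new, unique, unknown or untested is made for them only; others in the source may bear on it.

- Compound 1 `C[C@@H](O)[C@@H](CO)Nc1c(C(N)=O)cnn2cc(-c3ccccc3)cc12`: 70 nM
- Compound 2 `C[C@H](O)[C@@H](CO)Nc1c(C(N)=O)cnn2cc(-c3ccccc3)cc12`: 870 nM

In a functional assay on cells (T-cell, Homo sapiens) for inhibition, read by scintillation counting and thymidine incorporation, with stated times of 60 min and 3 days (on this read-out lower numbers stand for stronger inhibition and higher numbers for weaker inhibition), compound 2 gives 870 nM, the higher of the two numbers and so the weaker inhibition. Compound 3 `C[C@@H](O)[C@H](CO)Nc1c(C(N)=O)cnn2cc(-c3ccccc3)cc12` is its mirror image: the two compounds have the same atoms and bonds and differ only in configuration as drawn: 2 of 2 stereo elements differ (all stereocentres are inverted: mirror images); a stereocentre at a saturated chain carbon is drawn S in compound 2 and R in compound 3; a stereocentre at a saturated chain carbon is drawn R in compound 2 and S in compound 3. For the measured compounds named here, only one measured step bears on this change: a 12-fold higher number from compound 1 to compound 2 (1.09 log units; beyond the scatter). That large step comes with the fact that compounds 1 and 2 differ only in the configuration as drawn, so configuration alone can matter here. Going by the values given here, a step beyond the scatter is therefore expected again, though no measured step fixes its direction. The expected move, towards a lower number, is a 2.9-fold lower number from compound 2 to compound 3 (0.46 log units; beyond the scatter). For compound 3 the estimate is 300 nM, with an expected range from 70 nM to 1500 nM.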

Compound 3, half-maximal inhibitory concentration: 1800 nM
For compound 3 the middle estimate is 6.0-fold (0.78 log units) below the measured one, outside the stated range (above it).
By their numbers in this assay, from the lowest: compound 1; then compound 2; then compound 3.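

The other stereocentre of the chain matters too: in this assay, inverting it alone in compound 1 gives a 26-fold higher number from compound 1 to compound 3 (1.41 log units; beyond the scatter). So the number depends on this centre as well, not only on the one changed in compound 2, and the link to configuration is direct: the fact that compounds 1 and 3 differ only in the configuration as drawn Inverting both centres of compound 2 gives a 2.1-fold higher number from compound 2 to compound 3 (0.32 log units; beyond the scatter), so these mirror images are not equivalent, and compound 1 has the lowest number of the three.

As far as these compounds go, the mirror image of compound 1 remains open. So does whether an amine or a methyl ether could replace either hydroxyl while keeping the configuration of compound 1.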